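Compound 4: cyclopropylmethyl in place of azetidin-1-yl

A few compounds are considered here, and "the series" means these few. Any claim that something is new, unique, unknown or untested is made for them only; others in the source may bear on it.

In an in vivo ADME assay on the whole organism for metabolic stability, with Canis familiaris (Canis lupus familiaris) as the target, using cassette dosing, at a dose of 0.25 mg/kg by the intravenous route (a lower number here means that the compound disappears faster, a higher number that the compound lasts longer), compound 1 `CCCS(=O)(=O)N1CCC(CNC(=O)c2ccc(Cl)cc2Cl)(C2CCCCC2O)CC1` gives < 2 h, which is a limit. Compound 2 `CCCS(=O)(=O)N1CCC(CNC(=O)c2ccc(Cl)cc2Cl)(C2CCCCC2OC(C)=O)CC1` gives < 2 h, also a limit. Compound 3 `CCCS(=O)(=O)N1CCC(CNC(=O)c2ccc(Cl)cc2Cl)(N2CCC2)CC1` gives < 2 h, again a limit and not a number. The series therefore rests on (the limit of < 2 h in this assay, at which 3 of the 3 values shown sit).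

Compound 4 `CCCS(=O)(=O)N1CCC(CNC(=O)c2ccc(Cl)cc2Cl)(CC2CC2)CC1` differs from compound 3 by cyclopropylmethyl in place of azetidin-1-yl on a saturated ring carbon. Two measured changes at the same saturated ring carbon bear on it: a step that the two limits leave unreadable from compound 1 to compound 3 and a step that the two limits leave unreadable from compound 2 to compound 3. Neither gives a usable size or direction, so no step beyond the scatter is expected. The expected change is a step that the limit leaves unreadable from compound 3 to compound 4, with no firm direction. The estimate for compound 4 is 1.2 h, with an expected range of 0.5 h to 2.8 h.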

Compound 4, half-life: < 2 h
Compound 4 ended at the assay's limit (the forecaster's own chance of this, stated with the estimate: 65%); the middle value is on the limit's open side.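

No step can be read between compound 4 and compound 1, compound 2 or compound 3, since all of them share one limit: the limit of < 2 h in this assay, at which 4 of the 4 values shown sit.

Going by these compounds, the actual half-lives in this assay remain open, as does any effect of changing the group on this saturated ring carbon.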